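The source may report more compounds than this note shows. Statements on the series, on what has been measured and on what is new or still open speak of the compounds shown alone.

Measured compounds:
compound 1, `OC[C@H](NC[C@H]1NC[C@H](O)[C@@H]1O)c1ccc(-c2ccccc2)cc1`: > 200000 nM
compound 2, `OC[C@H](NC[C@H]1NC[C@H](O)[C@@H]1O)c1ccc(-c2ccc(C(F)(F)F)cc2)cc1`: 80000 nM

In a functional assay on U-87MG ATCC cells (Homo sapiens) for cytotoxicity, read by colorimetric assay, with a stated time of 72 h (on this read-out lower numbers stand for stronger inhibition and higher numbers for weaker inhibition), compound 1 returns only a limit, > 200000 nM, so its standing is a bound rather than a number. In this assay compound 2 gives 80000 nM. The measured step is an at least 2.5-fold lower number from compound 1 to compound 2 (0.39 log units; beyond the scatter), for trifluoromethyl in place of hydrogen on an aromatic carbon, and its size rests on (the limit of > 200000 nM in this assay, at which 1 of the 2 values shown sits).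

Compound 3, `OC[C@H](NC[C@H]1NC[C@H](O)[C@@H]1O)c1ccc(OCc2ccccc2)cc1`, differs from compound 1 in benzyloxy in place of phenyl on an aromatic carbon. Among the compounds with values here, no measured step covers benzyloxy in place of phenyl; the one step available concerns a different change and does not bear on this one. Compound 1 itself sits only at a limit, so the starting point is uncertain. The expectation for compound 3 in this assay is therefore no step beyond the scatter, with a fair chance that again only a limit is returned. Compound 3 is expected to give about 150000 nM, in the range 60000 nM to 300000 nM. This corresponds to an expected at least 1.3-fold lower number from compound 1 to compound 3 (0.12 log units; that floor lies within the scatter).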

Compound 3, half-maximal inhibitory concentration: "not active" (no number reported)
Compound 3 has no reported number here; the estimate stays without a comparison.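

No new step can be read between compound 1 and compound 3: in this assay compound 3 is reported only as "not active", without a number. Compound 1 gives > 200000 nM, which is a limit and not a number. The compounds shown leave open whether benzyloxy in place of phenyl shifts this read-out at all.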